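The compounds below may be only part of what the source reports. "The series", "measured", "known", "first", "only" and "open" are said of these compounds alone.

Three ureas sharing one core have been measured in a functional assay on HepG2 cells (Homo sapiens) for antiproliferative activity, read by MTT assay, with a stated time of 48 h; on this read-out higher numbers stand for weaker inhibition and lower numbers for stronger inhibition. Compound 1 `Cc1ccc(NC(=O)Nc2cccc(CNc3nccnc3Cl)c2)cc1C` gives 10700 nM. Compound 2 `O=C(Nc1cccc(CNc2nccnc2Cl)c1)Nc1ccccc1F` gives 10500 nM. Compound 3 `O=C(Nc1cccc(CNc2nccnc2Cl)c1)Nc1ccc(F)c(Cl)c1` gives 6750 nM, the lowest of the three numbers, though its gaps to the others, a 1.6-fold lower number from compound 1 to compound 3 (0.20 log units; within the scatter) and a 1.6-fold lower number from compound 2 to compound 3 (0.19 log units; within the scatter), both lie within the scatter. The next compound, compound 4 `COc1ccc(NC(=O)Nc2cccc(CNc3nccnc3Cl)c2)cc1`, is not yet measured; it carries 4-methoxyphenyl in place of 3-chloro-4-fluorophenyl on an amide-type nitrogen. Every step seen so far swaps the aryl group on that same amide-type nitrogen, and none left the scatter: a 1.0-fold lower number from compound 1 to compound 2 (0.01 log units; within the scatter), a 1.6-fold lower number from compound 1 to compound 3 (0.20 log units; within the scatter), a 1.6-fold lower number from compound 2 to compound 3 (0.19 log units; within the scatter). On that basis no step beyond the scatter is expected in this assay; the expected step is a 1.2-fold higher number from compound 3 to compound 4 (0.07 log units; within the scatter). Compound 4 is therefore estimated at 8000 nM, within a range from 4000 nM to 16000 nM.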

Compound 4, half-maximal inhibitory concentration: 12000 nM
For compound 4 the middle estimate is 1.5-fold (0.18 log units) below the measured one, within the range that was stated.
By their numbers in this assay, from the lowest: compounds 3, 2, 1 and 4 (each within the scatter of the next).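

Among the compounds shown here, the 4-methoxyphenyl group is the first aryl group at this position to carry oxygen, and in this assay the steps are a 1.8-fold higher number from compound 3 to compound 4 (0.25 log units; within the scatter) and a 1.1-fold higher number from compound 2 to compound 4 (0.06 log units; within the scatter) and a 1.1-fold higher number from compound 1 to compound 4 (0.05 log units; within the scatter) with none leaving the scatter. All four aryl groups on this amide-type nitrogen, including the one with a hydrogen-bond acceptor, thus give numbers that cannot be told apart. Nothing available explains this flat result. Every step shown lies on this one nitrogen, so any change in the shared core remains open. Also open, on these data alone, is whether an amine or a carboxylic acid on the aryl ring, or a longer alkyl chain in its place, would move the number beyond the scatter.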